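Demethylation of compound 2: a single-atom change

A few compounds are considered here, and "the series" means these few. Any claim that something is new, unique, unknown or untested is made for them only; others in the source may bear on it.

Compound 2, `COc1cc(C)cc(-c2nn(CC#N)cc2-c2ccnc(-c3ccc(N(C)C)cc3)c2)c1`, was tested in a functional assay on MDA-MB-231 cells (Homo sapiens) for cytotoxicity, read by sulforhodamine B assay, with a stated time of 48 h, tested at 1 uM (a lower number here means a stronger effect, a higher number a weaker effect of the compound at the concentration tested), where compound 2 gives -15%. Compound 1, `Cc1cc(O)cc(-c2nn(CC#N)cc2-c2ccnc(-c3ccc(Oc4ccccc4)cc3)c2)c1`, sits within the usual scatter of that figure, since in this assay compound 1 gives -13%. Compound 3, `Cc1cc(O)cc(-c2nn(CC#N)cc2-c2ccnc(-c3ccc(N(C)C)cc3)c2)c1`, has not been measured. Its difference from compound 2 is hydrogen in place of methyl on an oxygen on an aromatic ring. Among the measured compounds shown here, no step between two measured compounds bears on this change, so compound 3 is expected to move little beyond the scatter, the step from compound 2 to compound 3 being estimated at a number 1 percentage points higher from compound 2 to compound 3 (within the scatter). Compound 3 is therefore expected to give about -14%, within a range of -30% to 5%.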

Compound 3, a percentage reported as activity, at one concentration (the size of the read-out at that concentration, not a potency): 11%
Estimate against measurement, compound 3: 25 percentage points below; the measured number lies above the stated range.
By their numbers in this assay, from the lowest: compounds 2 and 1 (each within the scatter of the next); then compound 3.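

In this assay, the methyl on this oxygen counts: going from methoxy to hydroxy weakens the effect at the concentration tested (a number 26 percentage points higher from compound 2 to compound 3 (beyond the scatter)). With the hydroxy kept, dimethylamino in place of phenoxy on an aromatic carbon also weakens it (a number 24 percentage points higher from compound 1 to compound 3 (beyond the scatter)), so the closeness of compound 1 and compound 2, which differ in two places, did not mean that either place was silent. No measurement available here explains either step. Going by these compounds, whether a longer chain on that oxygen, such as ethoxy, or an amine in place of the hydroxy would follow methoxy or hydroxy stays open.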